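A few compounds are considered here, and "the series" means these few. Any claim that something is new, unique, unknown or untested is made for them only; others in the source may bear on it.

Working notes on the series.

Compound 1 `C#CCNC1CCc2c(SCCc3cccc(C)c3)cccc21` and compound 2 `C#CCNC1CCc2c(SCCc3cccc(F)c3)cccc21` share a core with compound 3 `C#CCNC1CCc2c(SCCc3ccc(F)c(F)c3)cccc21` and compound 4 `C#CCNC1CCc2c(SCCc3ccc(Cl)c(Cl)c3)cccc21` and differ only in the substituent on the phenyl ring at the end of the chain. In an ADME assay on isolated protein for inhibition of Amine oxidase [flavin-containing] B (Homo sapiens) (a lower number here means a stronger inhibitor, a higher number a weaker inhibitor), compound 1 gives 4960 nM and compound 2 gives 7810 nM; the step of a 1.6-fold higher number from compound 1 to compound 2 (0.20 log units; within the scatter) is a change of fluoro in place of methyl on an aromatic carbon. In this assay, for the measured compounds named here, compound 3 gives "not determined" (no result reported), so it stands without a number of its own; the only numbers are those of compound 1 and compound 2.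

The step to compound 4 is 3,4-dichlorophenyl in place of 3,4-difluorophenyl on a saturated chain carbon, two bonds along the chain from a sulfur. Going by the values given here, no measured pair shows a halogen exchange of this kind, and the single measured step, from methyl to fluoro, lay within the scatter, so nothing in hand points to a large step in either direction in this assay. The expectation for compound 4 is therefore anchored on the values of compound 1 and compound 2, with a wide range. Compound 4 is estimated at 3500 nM in this assay, expected to fall between 800 nM and 15000 nM.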

Compound 4, half-maximal inhibitory concentration: 2820 nM
The estimate for compound 4 lay 1.2-fold (0.09 log units) above the measured number; the range from low to high includes it.
By their numbers in this assay, from the lowest: compounds 4, 1 and 2 (each within the scatter of the next, the first and the last beyond it).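

Working from this assay, replacing 3-fluorophenyl on the saturated chain carbon, two bonds along the chain from a sulfur, with 3,4-dichlorophenyl gives a 2.8-fold lower number from compound 2 to compound 4 (0.44 log units; beyond the scatter) and is the first step in the series to stand beyond the scatter, though it is modest. Replacing 3-methylphenyl at the same place with 3,4-dichlorophenyl gives a 1.8-fold lower number from compound 1 to compound 4 (0.25 log units; within the scatter) so no order can be stated for that pair. No measurement in hand explains the result for compound 4.

From the compounds shown here alone, the step from compound 3 to compound 4 cannot be read, as compound 3 has no number, so the exchange of 3,4-difluorophenyl for 3,4-dichlorophenyl remains open. Also open, going by these compounds, is how an amine or a carboxylic acid on the phenyl ring, or a longer chain, would behave in this assay at this position.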